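The source may report more compounds than this note shows. Statements on the series, on what has been measured and on what is new or still open speak of the compounds shown alone.

In a functional assay on A549 cells (Homo sapiens) for cytotoxicity, read by MTT assay, with a stated time of 72 h (a higher number here means a weaker inhibitor, a lower number a stronger inhibitor), compound 3 `CC(=O)Nc1nnc(-c2ccc(O)c(O)c2)s1`, which carries a methyl on the carbonyl carbon, gives 133000 nM. Among the compounds with values here, that is the highest number of the three measured so far, which makes it the weakest inhibitor among them. With cyclohexyl at that place, compound 1 `O=C(Nc1nnc(-c2ccc(O)c(O)c2)s1)C1CCCCC1` gives 16300 nM, and with 4-chlorophenyl, compound 2 `O=C(Nc1nnc(-c2ccc(O)c(O)c2)s1)c1ccc(Cl)cc1` gives 14600 nM. Compound 4 `O=C(Nc1nnc(-c2ccc(O)c(O)c2)s1)c1ccccc1` has not yet been measured. It has phenyl in place of methyl on a carbonyl carbon. Within the data shown here, two measured steps bear most directly on this change, since both end at the methyl: an 8.2-fold higher number from compound 1 to compound 3 (0.91 log units; beyond the scatter) and a 9.1-fold higher number from compound 2 to compound 3 (0.96 log units; beyond the scatter). Both lie beyond the scatter. The two larger ring groups themselves differ by little, with a 1.1-fold lower number from compound 1 to compound 2 (0.05 log units; within the scatter). Phenyl also brings a ring, so the change to compound 4 should roughly reverse those two steps, though only two ring groups have been measured. The expected step, towards a lower number, is a 6.7-fold lower number from compound 3 to compound 4 (0.82 log units; beyond the scatter). For compound 4, the estimated value is 20000 nM, within an expected range of 8000 nM to 45000 nM.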

Compound 4, half-maximal inhibitory concentration: 13000 nM
Compound 4: middle estimate off by 1.5-fold (0.19 log units), on the high side; measured number inside the range.
By their numbers in this assay, from the lowest: compounds 4, 2 and 1 (each within the scatter of the next); then compound 3.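

In this assay, plain phenyl on the carbonyl carbon gives the full change seen with the larger ring groups, with a 10-fold lower number from compound 3 to compound 4 (1.01 log units; beyond the scatter), and the chloro of compound 2 adds nothing that can be detected, since swapping it for hydrogen gives a 1.1-fold lower number from compound 2 to compound 4 (0.05 log units; within the scatter). An aromatic ring and a saturated ring also cannot be told apart at this place, with a 1.3-fold lower number from compound 1 to compound 4 (0.10 log units; within the scatter), so among these groups the large difference lies between methyl and any of the three rings. No measurement here gives a reason for this result.

On these data alone, it remains open whether a ring as such is needed or whether more carbon atoms would do the same, which a longer chain such as butyl on the carbonyl carbon could test. As far as these compounds go, it is also open whether phenyl bearing an amine or a carboxylic acid would keep this level of activity.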